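Swapping phenyl for pyridin-3-yl on the benzoyl hydrazone

The compounds below may be only part of what the source reports. "The series", "measured", "known", "first", "only" and "open" are said of these compounds alone.

Measured so far:
compound 1, `COc1cccc(/C=N\NC(=O)C2=C(Cl)c3ccccc3CCC2)c1`: < 10 nM
compound 2, `O=C(N/N=C\C1=C(Cl)c2ccccc2CCC1)C1=C(Cl)c2ccccc2CCC1`: 2200 nM
compound 3, `O=C(N/N=C/C1=C(Cl)c2ccccc2CCC1)c1ccccc1`: 16100 nM

In a functional assay on IMR-32 cells (Homo sapiens) for inhibition, read by sulforhodamine B assay, with a stated time of 48 h (a lower number here means a stronger inhibitor of growth, a higher number a weaker inhibitor of growth), compound 1 reaches only the limit of the assay, < 10 nM, so no number is known for it (the limit of < 10 nM in this assay, at which 1 of the 3 values shown sits). Of the two numbers that exist, compound 3 has the highest; compound 2 sits lower, and that gap lies beyond the scatter. Compound 4, `O=C(N/N=C/C1=C(Cl)c2ccccc2CCC1)c1cccnc1`, is compound 3 with a change on the carbonyl carbon: pyridin-3-yl in place of phenyl on a carbonyl carbon. Nothing measured here shows what such a change does, so the step of a 1.3-fold lower number from compound 3 to compound 4 (0.13 log units; within the scatter) is expected to stay within the scatter, in no firm direction. For compound 4 the expected value in this assay is 12000 nM, with a likely range from 3000 nM to 40000 nM.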

Compound 4, concentration for 50% growth inhibition: 150 nM
The estimate for compound 4 lay 80-fold (1.90 log units) above the measured number; measured number below the stated range.
By their numbers in this assay, from the lowest: compound 4; then compound 2; then compound 3. At a limit, below all of these: compound 1.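

In this assay, pyridin-3-yl in place of phenyl on a carbonyl carbon gives a 110-fold lower number from compound 3 to compound 4 (2.03 log units; beyond the scatter) and so shows that growth inhibition depends strongly on the ring held at this position. Among these compounds, the earlier compounds offered no pair differing in one place, so this is the first direct reading of any single change. Nothing shown here explains why one ring nitrogen makes so large a difference.

From the compounds shown here alone, it remains open how pyridin-2-yl or pyridin-4-yl would behave on the same carbonyl carbon. A phenyl ring carrying an amine or a carboxylic acid is also absent from the compounds shown.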